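A Bromo for Fluoro Swap on Compound 2

The source may report more compounds than this note shows. Statements on the series, on what has been measured and on what is new or still open speak of the compounds shown alone.

In a functional assay on HepG2 cells (Homo sapiens) for cytotoxicity, read by MTT assay, with a stated time of 24 h (on this read-out higher numbers stand for weaker inhibition and lower numbers for stronger inhibition), compound 1 (`O=C1/C(=C/c2ccncc2)CN(S(=O)(=O)c2ccc(Br)cc2)C/C1=C\c1ccccc1F`) gives 9300 nM while compound 2 (`O=C1/C(=C/c2ccncc2)CN(S(=O)(=O)c2ccc(F)cc2)C/C1=C\c1ccccc1C(F)(F)F`) gives 4010 nM as the lower of the two numbers, a gap beyond the scatter. Compound 3 (`O=C1/C(=C/c2ccncc2)CN(S(=O)(=O)c2ccc(Br)cc2)C/C1=C\c1ccccc1C(F)(F)F`) matches compound 2 except for bromo in place of fluoro on an aromatic carbon and so carries the 4-bromophenyl of compound 1. Compound 1 and compound 2 differ in more than one place, so their gap does not isolate this swap. The expected step of a 1.1-fold higher number from compound 2 to compound 3 (0.05 log units; within the scatter) in this assay lies within the scatter, with no direction favoured. Compound 3 is estimated at 4500 nM within a range of 2000 nM to 10000 nM on that expectation.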

Compound 3, half-maximal inhibitory concentration: 14500 nM
Compound 3: the middle estimate sits 3.2-fold (0.51 log units) below what was measured; the whole stated range lies below it.
By their numbers in this assay, from the lowest: compound 2; then compounds 1 and 3 (each within the scatter of the next).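

With the trifluoromethyl group held fixed in this assay, going from 4-fluorophenyl to 4-bromophenyl gives a 3.6-fold higher number from compound 2 to compound 3 (0.56 log units; beyond the scatter) and so shows that this halogen swap can shift the read-out. With the 4-bromophenyl held fixed, trifluoromethyl in place of fluoro on the other aromatic ring gives a 1.6-fold higher number from compound 1 to compound 3 (0.19 log units; within the scatter) and leaves the two compounds within the scatter of each other. Nothing available explains why the bromo for fluoro swap has this effect.

Going by these compounds, whether that swap has the same effect when the other ring carries fluoro remains open. So does how an amine or a methoxy group would read at this position.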